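Methoxy for methyl on a heptanoyl pyrrolidine amide

This account rests on a few compounds, and the source may have more. Where it says the series, first, only, none or still open, it means among the compounds named here.

Three compounds share a pyrrolidine amide with an aryl group on the chain, and all three have been tested in an assay on HEK293 cells for inhibition of N-acylethanolamine-hydrolyzing acid amidase (Rattus norvegicus), read by LC-MS, with a stated time of 30 min; a lower number here means a stronger inhibitor, a higher number a weaker inhibitor. Compound 1 `Cc1cccc(CCCCCCC(=O)N2CCCC2)c1` gives 8300 nM. Compound 2 `O=C(CCCCCCc1ccc(Cl)cc1)N1CCCC1` gives 34500 nM in this assay, and compound 3 `O=C(CCc1ccc(-c2ccc(Cl)cc2)cc1)N1CCCC1` gives 48600 nM. Among these three numbers compound 1 has the lowest, and its distance to compound 2 and to compound 3 is in each case beyond the scatter of repeated measurements, so compound 1 is the strongest inhibitor of the three shown here.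

The next compound, compound 4 `COc1cccc(CCCCCCC(=O)N2CCCC2)c1`, differs from compound 1 in one place only: methoxy in place of methyl on an aromatic carbon. The aromatic ring, its six-carbon chain and the pyrrolidine amide are otherwise unchanged. Among the measured compounds shown here, no pair of measured compounds shows what this exchange does, so the expectation rests on the small size of the change alone: a step in this assay from compound 1 to compound 4 that is no larger than the scatter, in either direction. The value estimated for compound 4 is 7000 nM, with a range from 2500 nM to 20000 nM, meaning an expected step of a 1.2-fold lower number from compound 1 to compound 4 (0.07 log units; within the scatter).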

Compound 4, half-maximal inhibitory concentration: > 100000 nM
Compound 4 ended at the assay's limit; the forecaster's own chance of this, stated with the estimate: 5%; middle value at least 14-fold (1.15 log units) away from the limit.
By their numbers in this assay, from the lowest: compound 1; then compounds 2 and 3 (each within the scatter of the next). At a limit, above all of these: compound 4.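

Compound 4 gives > 100000 nM in this assay, and this is a limit of the assay, not a number. The earlier compounds shown here gave no view of this aromatic carbon, meta to a large group, and the exchange of methyl for methoxy there now shows that a very small edit to the core of compound 1 can be far from neutral, with an at least 12-fold higher number from compound 1 to compound 4 (1.08 log units; beyond the scatter). That step is itself only a lower bound, so the true distance between the two compounds cannot be read, and the limit is the only thing recorded about the result, which offers no measured explanation for the loss: the limit of > 100000 nM in this assay, at which 1 of the 4 values shown sits.

The compounds shown leave open whether the loss follows the oxygen itself or simply the longer substituent, a question that ethyl or hydroxyl on the same aromatic carbon would help to settle. They also leave open whether methoxy in place of methyl would have the same outcome on a longer chain, or with a piperidine amide in place of the pyrrolidine amide.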